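Bromo in place of methyl across two cores

The compounds below may be only part of what the source reports. "The series", "measured", "known", "first", "only" and "open" are said of these compounds alone.

Compound 1 `Cc1ccc(S(=O)(=O)c2ccc(NC(=O)C(C)(O)C(F)(F)F)cc2)cc1` and compound 2 `CC(O)(C(=O)Nc1ccc(S(=O)(=O)c2ccc(Br)cc2)cc1)C(F)(F)F` share one core; compound 3 `Cc1cc(C(=O)c2ccccc2)ccc1NC(=O)C(C)(O)C(F)(F)F` and compound 4 `CC(O)(C(=O)Nc1ccc(C(=O)c2ccccc2)cc1Br)C(F)(F)F` share another, and the difference between the two cores is not broken down here. In a functional assay (Cavia porcellus) with sulfonylurea receptors; K-ATP channels (Homo sapiens) as the target (a higher number here means a weaker inhibitor, a lower number a stronger inhibitor), compound 1 gives > 30000 nM, which is a limit of the assay and not a number. In this assay compound 2 likewise gives > 30000 nM, again a limit. In this assay, among the compounds with values here, compound 3 gives 5000 nM, the only number among the three measured values. The measured step is a step that the two limits leave unreadable from compound 1 to compound 2, the change being (bromo in place of methyl on an aromatic carbon); its size stays unreadable because of the limit of > 30000 nM in this assay, at which 2 of the 3 values shown sit. The same kind of change, (bromo in place of methyl on an aromatic carbon), leads to compound 4; around the place the two cases differ, the first being para to a large group, the second ortho to a large group and meta to a benzoyl group. With the measured step unreadable, the expectation rests on compound 3 alone and on an exchange that leaves one heavy atom and brings in one; the step is estimated as no change at the digits printed from compound 3 to compound 4 (within the scatter). For compound 4 in this assay the estimate is 5000 nM, with a range from 1500 nM to 15000 nM.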

Compound 4, half-maximal inhibitory concentration: > 30000 nM
Compound 4: no number, only a limit; the forecaster's own chance of this, stated with the estimate: 20%; middle value at least 6.0-fold (0.77 log units) from the limit.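

In this assay, bromo in place of methyl on an aromatic carbon, ortho to a large group and meta to a benzoyl group, gives an at least 6.0-fold higher number from compound 3 to compound 4 (0.77 log units; beyond the scatter), so in the core of compound 3 this change weakens inhibition by a margin that can be read only as a minimum. Compound 4 gives > 30000 nM, which is a limit of the assay and not a number. The step from compound 1 to compound 2 cannot be read, and the result therefore does not show whether the change carries over between the two cores with a similar size, because so few values lie within the measurable range: the limit of > 30000 nM in this assay, at which 3 of the 4 values shown sit.

Within the data shown here, compound 3, at 5000 nM, holds the only number in the set, so it remains open how fluoro, chloro or an amine at that same place would read. Also open, on these data alone, is how the core of compound 1 responds to this change when the starting compound gives a number rather than a limit.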